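This account rests on a few compounds, and the source may have more. Where it says the series, first, only, none or still open, it means among the compounds named here.

Compound 1 `CC(O)(COc1cc(C(F)(F)F)cc(C(F)(F)F)c1)C(=O)Nc1cccc(S(F)(F)(F)(F)F)c1` and compound 2 `CC(O)(COc1ccc(S(F)(F)(F)(F)F)cc1)C(=O)Nc1cc(C(F)(F)F)cc(C(F)(F)F)c1` are built from the same atoms joined differently; the difference between the two cores is not broken down here. In a functional assay on LNCaP cells (Homo sapiens) for antiproliferative activity, read by propidium iodide staining, with a stated time of 96 h (on this read-out lower numbers stand for stronger inhibition and higher numbers for weaker inhibition), compound 1 gives 2800 nM, and compound 2 gives 1900 nM. Compound 3 `CC(O)(COc1ccc(C(F)(F)C(F)(F)F)cc1)C(=O)Nc1cc(C(F)(F)F)cc(C(F)(F)F)c1` arises from compound 2 by a group of 7 heavy atoms (2 carbon, 5 fluorine; no ring) in place of a group of 6 heavy atoms (5 fluorine, 1 sulfur; no ring), on an aromatic carbon; in this assay compound 3 gives 2700 nM, which is a 1.4-fold higher number from compound 2 to compound 3 (0.15 log units; within the scatter). Compound 4 `CC(O)(COc1cc(C(F)(F)F)cc(C(F)(F)F)c1)C(=O)Nc1cccc(C(F)(F)C(F)(F)F)c1`, not yet measured, arises from compound 1 by a group of 7 heavy atoms (2 carbon, 5 fluorine; no ring) in place of a group of 6 heavy atoms (5 fluorine, 1 sulfur; no ring), on an aromatic carbon. This is the same kind of change, not the same: in compound 3 the entering group sits para to a large group, in compound 4 meta to a large group. For compound 4 a step of a 1.3-fold higher number from compound 1 to compound 4 (0.10 log units; within the scatter) is expected. That expectation rests on the earlier step, because a 1.4-fold higher number from compound 2 to compound 3 (0.15 log units; within the scatter) stayed within the scatter. Compound 4 is therefore estimated at 3500 nM, between 1700 nM and 7500 nM.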

Compound 4, half-maximal inhibitory concentration: 4700 nM
Compound 4: the middle estimate sits 1.3-fold (0.13 log units) below what was measured; the range from low to high includes it.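

Within this assay, putting 1,1,2,2,2-pentafluoroethyl in place of the sulfur group bearing five fluorines on the core of compound 1 gives a 1.7-fold higher number from compound 1 to compound 4 (0.22 log units; within the scatter). Set beside the same swap on the other core, the two steps agree: the same change on two cores in this assay, a 1.4-fold higher number (0.15 log units; within the scatter) from compound 2 to compound 3 and a 1.7-fold higher number (0.22 log units; within the scatter) from compound 1 to compound 4, 1.2-fold (0.07 log units) apart, within the scatter of two such steps. On these two cores, then, the swap carries over as a step too small to tell apart from repeat-measurement scatter, but two pairs give no rule for other cores and do not prove that the two groups are truly equal.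

The compounds shown leave open what an amine, a carboxylic acid or a longer fluorinated chain would do at this place. They also leave open whether the swap stays this small on a different core.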